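A Sulfonamide Swap on a Poorly Stable Core

This account rests on a few compounds, and the source may have more. Where it says the series, first, only, none or still open, it means among the compounds named here.

Compound 1 `O=S(=O)(c1cccc(-c2ccc3nccc(-c4ccncc4)c3n2)c1)N1CCC(O)CC1`: 5%
Compound 2 `O=S(=O)(NCCO)c1cccc(Nc2ccc3nccc(-c4ccncc4)c3n2)c1`: 59%
Compound 3 `NS(=O)(=O)c1ccc(-c2ccc3nccc(-c4ccncc4)c3n2)cc1`: 76%

All three compounds share a core and were tested in an ADME assay on microsomes from liver (Homo sapiens) for metabolic stability, read by LC-MS, using NADPH, with a stated time of 30 min, tested at 0.1 uM; on this read-out higher numbers stand for a more stable compound and lower numbers for a less stable compound. Compound 1 stands lowest of the three numbers. Its nearest neighbour is compound 2, whose value lies higher by a margin beyond the usual scatter, and furthest from it is compound 3, whose value lies higher still, again beyond the scatter. Among the compounds with values here, the set therefore places compound 1 clearly at the unstable end, with no pair among the measured compounds differing in only one place, so no single measured step can be used as a guide.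

Compound 4 `C[C@@H]1CN(S(=O)(=O)c2cccc(-c3ccc4nccc(-c5ccncc5)c4n3)c2)C[C@H](C)N1` has not yet been measured. It differs from compound 1 in one place:

3,5-dimethylpiperazin-1-yl in place of 4-hydroxypiperidin-1-yl on a sulfonyl sulfur

Within the data shown here, with no measured step to lean on, the direction of this change is open. Given that compound 1 gives 5% in this assay, there is little room for a downward move, so a modest upward step is expected, a number 15 percentage points higher from compound 1 to compound 4 (beyond the scatter), though a result within the scatter of compound 1 would not surprise. Compound 4 is thus estimated at 20%, with a range from 3% to 50%.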

Compound 4, percent of the compound remaining: 34%
Estimate against measurement, compound 4: 14 percentage points below; low and high end bracket the measured number.
By their numbers in this assay, from the lowest: compound 1; then compound 4; then compound 2; then compound 3.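

Within the data shown here, compound 1 and compound 4 give the first step in this set that can be read at a single place: with 3,5-dimethylpiperazin-1-yl in place of 4-hydroxypiperidin-1-yl on a sulfonyl sulfur, this assay shows a number 29 percentage points higher from compound 1 to compound 4 (beyond the scatter) and so shows that this position responds to the choice of ring on the sulfur. The donor and acceptor counts are the same for the two groups, so those counts do not separate them; what differs is the loss of the oxygen, the gain of a second ring nitrogen, the added carbon and the two defined stereocentres. Nothing measured here identifies which of these differences accounts for the step, and no supporting evidence bears on its cause.

On these data alone, whether the ring nitrogen alone or the two methyl groups and their stereochemistry carry the step remains open, and an unsubstituted piperazin-1-yl or a morpholin-4-yl group on the same sulfonyl sulfur would be the closest comparison. Compound 2 and compound 3 differ from compound 1 in more than one place, so they cannot show whether the step holds elsewhere on the shared core.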